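Oxolane attachment point shift on the shared core

This account rests on a few compounds, and the source may have more. Where it says the series, first, only, none or still open, it means among the compounds named here.

Measured so far in an assay on CHO-K1 cells for displacement of a labelled ligand from prostaglandin E2 receptor EP1 subtype (Homo sapiens); on this read-out lower numbers stand for stronger inhibition and higher numbers for weaker inhibition:
compound 1 `Cc1cc(C(=O)NC(C)C)nn1Cc1cc(Cl)ccc1OCc1ccccc1` — 126 nM
compound 2 `Cc1cc(NC(=O)C2CCCO2)nn1Cc1cc(Cl)ccc1OCc1ccccc1` — 39.8 nM

On these two numbers compound 2 stands lowest; the step of a 3.2-fold lower number from compound 1 to compound 2 (0.50 log units; beyond the scatter) lies beyond the scatter. Compound 3 `Cc1cc(NC(=O)C2CCOC2)nn1Cc1cc(Cl)ccc1OCc1ccccc1` keeps the same atoms as compound 2 and differs only by oxolan-3-yl in place of oxolan-2-yl on a carbonyl carbon. Within the data shown here, the single measured step exchanges one amide group for another and does not bear on moving the attachment point within the oxolane, so no step beyond the scatter is expected, estimated as a 1.3-fold higher number from compound 2 to compound 3 (0.10 log units; within the scatter). Compound 3 is therefore expected to give about 50 nM in this assay, estimated range 20 nM to 125 nM.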

Compound 3, half-maximal inhibitory concentration: 39.8 nM
For compound 3 the middle estimate is 1.3-fold (0.10 log units) above the measured one; the measured number falls inside the stated range.
By their numbers in this assay, from the lowest: compounds 2 and 3 (each within the scatter of the next); then compound 1.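

In this assay the shift from oxolan-2-yl to oxolan-3-yl on the carbonyl carbon gives no change at the digits printed from compound 2 to compound 3 (within the scatter) and so separates the two attachment points not at all. With a 3.2-fold lower number from compound 1 to compound 3 (0.50 log units; beyond the scatter) as the second step from the isopropylcarbamoyl compound, the lower number is seen with both oxolane attachments, not with oxolan-2-yl alone. No evidence at hand bears on why the two attachments read alike.

Open, going by these compounds, is whether a pyrrolidin-2-yl group, with nitrogen in the ring, or an open-chain methoxymethyl group would hold the number on this carbonyl carbon. Also open, on these data alone, is how a carboxylic acid on the oxolane would read.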